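Working notes: from compound 2 to compound 3

The source may hold more compounds than are shown below. What is called first, only, known or untested is meant among the compounds shown, and "the series" means these compounds.

Among the measured compounds shown here, in a functional assay on A549 cells (Homo sapiens) for inhibition, read by MTT assay, with a stated time of 48 h (a lower number here means a stronger inhibitor, a higher number a weaker inhibitor), compound 2 (`CS(=O)(=O)Nc1ccc(-n2cc(-c3ccccc3)nn2)cc1Oc1ccccc1`) gives 29900 nM and compound 1 (`CS(=O)(=O)Nc1ccc(-n2cc(COc3ccccc3Cl)nn2)cc1Oc1ccccc1`) gives 53800 nM as the only other number, so the two stand within the scatter of each other. Compound 3 (`Cc1ccc(OCc2cn(-c3ccc(NS(C)(=O)=O)c(Oc4ccccc4)c3)nn2)cc1`) carries (4-methylphenoxy)methyl in place of phenyl on an aromatic carbon of the five-membered aromatic ring with 3 nitrogen: (4-methylphenoxy)methyl in place of phenyl on an aromatic carbon is the counted difference. For the measured compounds named here, one measured step bears on this change: a 1.8-fold lower number from compound 1 to compound 2 (0.26 log units; within the scatter) (phenyl in place of (2-chlorophenoxy)methyl) and it lies within the scatter. Going by the values given here, compound 1 stands at 53800 nM in this assay and is the closest measured guide, although no measured compound carries the (4-methylphenoxy)methyl group. The expected change is a 1.4-fold higher number from compound 2 to compound 3 (0.15 log units; within the scatter) and nothing beyond the scatter is anticipated, with any drift toward the number of compound 1. For compound 3 the estimated value is 42000 nM with an expected range of 18000 nM to 95000 nM in this measurement.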

Compound 3, half-maximal inhibitory concentration: 8000 nM
The estimate for compound 3 lay 5.3-fold (0.72 log units) above the measured number, outside the stated range (below it).
By their numbers in this assay, from the lowest: compound 3; then compounds 2 and 1 (each within the scatter of the next).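

In this assay, the group on this aromatic carbon of the five-membered ring now separates compounds beyond the scatter: a 3.7-fold lower number from compound 2 to compound 3 (0.57 log units; beyond the scatter), whereas a 1.8-fold lower number from compound 1 to compound 2 (0.26 log units; within the scatter) stayed within it. The oxygen-linked side chain alone does not set the number, since compound 1 also carries one and a 6.7-fold lower number from compound 1 to compound 3 (0.83 log units; beyond the scatter), with 4-methylphenyl in place of 2-chlorophenyl on the oxygen. No measured property is available to account for either step.

The last step exchanges both the ring substituent and its ring location, so the compounds shown do not separate the contribution of the methyl, the chloro or their placement. As far as these compounds go, how a 4-chlorophenyl or 2-methylphenyl group would read remains open, as does an amine in place of the linking oxygen.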